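Hydroxy in place of methoxy on the pyrazole series

This account rests on a few compounds, and the source may have more. Where it says the series, first, only, none or still open, it means among the compounds named here.

Of the compounds shown here, three sharing one core have been measured in a functional assay on M14 cells (Homo sapiens) for cytotoxicity, read by sulforhodamine B assay, with a stated time of 48 h, tested at 100 nM; on this read-out lower numbers stand for a stronger effect and higher numbers for a weaker effect at the one concentration tested. Compound 1, `COc1cc(C)cc(-c2nn(CC#N)cc2-c2ccc(-c3cccc(C(C)=O)c3)nc2)c1`, gives 58%. Compound 2, `Cc1cc(O)cc(-c2nn(CC#N)cc2-c2ccnc(-c3ccc(Oc4ccccc4)cc3)c2)c1`, gives 94%. Compound 3, `COc1cc(C)cc(-c2nn(CC#N)cc2-c2ccnc(-c3ccc(N(C)C)cc3)c2)c1`, gives -12%, the lowest of the three numbers and therefore the strongest effect shown: its nearest neighbour on the scale is compound 1, and its furthest is compound 2, both separated from it by more than the usual scatter. Among the measured compounds shown here, no pair among the three differs in only one place, so no single step can be read directly from the measured compounds.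

Compound 4, `Cc1cc(O)cc(-c2nn(CC#N)cc2-c2ccnc(-c3ccc(N(C)C)cc3)c2)c1`, is not yet measured. It differs from compound 3 by hydrogen in place of methyl on an oxygen on an aromatic ring, that is, methoxy to hydroxy on the aryl ring. Compound 2 also carries the hydroxy group, but with a different aryl on the other side, so its number cannot be taken as a step for this change alone.

For compound 4 a moderate step upward in this assay is expected, that is, a weaker effect than compound 3, of the size a number 27 percentage points higher from compound 3 to compound 4 (beyond the scatter). Compound 4 is therefore estimated at 15%, with a range from -15% to 55%.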

Compound 4, a percentage reported as activity, at one concentration (the size of the read-out at that concentration, not a potency): 82%
Beside the measured number, compound 4's estimate is 67 percentage points below it, outside the stated range (above it).
By their numbers in this assay, from the lowest: compound 3; then compound 1; then compound 4; then compound 2.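

In this assay, the change from methoxy to hydroxy on the aryl ring gives a number 94 percentage points higher from compound 3 to compound 4 (beyond the scatter), so with dimethylamino held constant, this one position separates the strongest effect among the compounds from a much weaker one. With the hydroxy group held constant, dimethylamino in place of phenoxy gives only a number 12 percentage points lower from compound 2 to compound 4 (beyond the scatter), so the aryl change that looked able to account for the low number of compound 3 moves the result far less than the change on the oxygen does. The compounds shown offer no measurement that accounts for the size of this step.

Going by these compounds, it remains open whether an ethoxy or an amino group in place of the hydroxy on the same ring would give a number closer to that of compound 3 or to that of compound 4. On these data alone, it is also open whether methoxy to hydroxy moves the number as far when phenoxy stands in place of dimethylamino, or when the other side of the molecule is that of compound 1.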